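Removing a Methoxy From a Quinolinyl Benzoxazinone

The source may report more compounds than this note shows. Statements on the series, on what has been measured and on what is new or still open speak of the compounds shown alone.

Measured compounds in a functional assay on HepG2 cells (Homo sapiens) for antiproliferative activity, read by MTT assay, with a stated time of 72 h; a higher number here means a weaker inhibitor, a lower number a stronger inhibitor:
compound 1, `O=C1COc2ccc(-c3cccc(NS(=O)(=O)c4ccc(F)cc4)c3)cc2N1C1CC1`: > 40000 nM
compound 2, `COc1ccc(N2C(=O)COc3ccc(-c4cnc5ccccc5c4)cc32)cc1`: > 40000 nM

Compound 1 reaches only the limit of this assay, and its value is not a number. Compound 2 likewise gives only the limit of this assay, so no number stands for it either. Both values sit at the limit of > 40000 nM in this assay, at which 2 of the 2 values shown sit, so compound 2 is not separated from compound 1 by any measured step; the two show the same limit. Compound 3, `O=C1COc2ccc(-c3cnc4ccccc4c3)cc2N1c1ccccc1`, differs from compound 2 in one place: hydrogen in place of methoxy on an aromatic carbon. Among the compounds with values here, no step between measured compounds is available to guide this change. Compound 3 is therefore expected to stay close to compound 2, with a step that the limit leaves unreadable from compound 2 to compound 3 that is expected to lie within the scatter, and most likely again to reach only the limit. Compound 3 is estimated at 50000 nM, within a range from 12000 nM to 200000 nM.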

Compound 3, half-maximal inhibitory concentration: > 40000 nM
Compound 3: only a limit was reported; the forecaster's own chance of this, stated with the estimate: 80%; the middle value is on the limit's open side.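

Within the data shown here, compound 3, like compound 2, reaches only a limit of the assay, so no step between the two can be read: the limit of > 40000 nM in this assay, at which 3 of the 3 values shown sit. The compounds shown leave open what the change from 4-methoxyphenyl to phenyl does in this assay, where none of them gives a number.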